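The source may hold more compounds than are shown below. What is called first, only, known or untested is meant among the compounds shown, and "the series" means these compounds.

Measured so far in a functional assay on SF-268 cells (Homo sapiens) for cytotoxicity, read by sulforhodamine B assay, with a stated time of 48 h; on this read-out higher numbers stand for weaker inhibition of growth and lower numbers for stronger inhibition of growth:
- compound 1 `ClCc1ccccc1Cn1cnc2c(Cl)nc(Cl)nc21`: 4160 nM
- compound 2 `ClCc1cccc(Cn2cnc3c(Cl)nc(Cl)nc32)c1`: 6600 nM
- compound 3 `Nc1nc(Cl)c2ncn(Cc3ccccc3CCl)c2n1`: 14500 nM

Compound 1 and compound 2 are built from the same atoms joined differently; the difference between the two cores is not broken down here. Their values in this assay lie within the scatter of each other. Compound 3 carries the change (amino in place of chloro on an aromatic carbon), and that change gave a 3.5-fold higher number from compound 1 to compound 3 (0.54 log units; beyond the scatter).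

Compound 4 `Nc1nc(Cl)c2ncn(Cc3cccc(CCl)c3)c2n1` is not yet measured. It differs from compound 2 by amino in place of chloro on an aromatic carbon, the same change as from compound 1 to compound 3, at the same place. The expectation is that it moves in the same direction and by a comparable size, an estimated 3.5-fold higher number from compound 2 to compound 4 (0.54 log units; beyond the scatter), resting on compound 3 having given a 3.5-fold higher number from compound 1 to compound 3 (0.54 log units; beyond the scatter). Compound 4 is therefore expected near 23000 nM, with 11000 nM to 48000 nM as the likely range.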

Compound 4, concentration for total growth inhibition: 10200 nM
Beside the measured number, compound 4's estimate is 2.3-fold (0.35 log units) above it, outside the stated range (below it).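

In this assay, amino in place of chloro on the core of compound 2 gave a 1.5-fold higher number from compound 2 to compound 4 (0.19 log units; within the scatter), whereas the same change on the core of compound 1 gave a step beyond the scatter. Set side by side, the two steps cannot be told apart: the same change on two cores in this assay, a 3.5-fold higher number (0.54 log units; beyond the scatter) from compound 1 to compound 3 and a 1.5-fold higher number (0.19 log units; within the scatter) from compound 2 to compound 4, 2.3-fold (0.35 log units) apart, within the scatter of two such steps. The change therefore carries between these two cores without a detectable difference in size, but two pairs neither fix that size precisely nor show that it holds on any other core.

Open, as far as these compounds go, is whether a methylamino or a hydroxyl group in the same place would give a step like that of amino. Also open, from the compounds shown here alone, is what a methyl or hydroxymethyl group in place of the chloromethyl group would do.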